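The source may report more compounds than this note shows. Statements on the series, on what has been measured and on what is new or still open speak of the compounds shown alone.

Measured so far in a physicochemical assay for solubility, measured as kinetic solubility; a higher number here means a more soluble compound, a lower number a less soluble compound:
- Compound 1 `O=C(Nc1ccnnc1)c1cc(C(F)(F)F)ccc1OCc1ccccc1`: < 1000 nM, a limit of the assay and not a number
- Compound 2 `O=C(Nc1ccnnc1)c1cc(N2CCCC2)ccc1OCc1ccccc1`: 35000 nM
- Compound 3 `C[C@@H]1CN(c2ccc(OCc3ccccc3)c(C(=O)Nc3ccnnc3)c2)C[C@H](C)O1`: 29000 nM

Compound 3, at 29000 nM, lies within the scatter of compound 2, at 35000 nM. Compound 4 `O=C(Nc1ccnnc1)c1cc(N2CCC(O)CC2)ccc1OCc1ccccc1` has not yet been measured. It carries 4-hydroxypiperidin-1-yl in place of 2,6-dimethylmorpholin-4-yl on an aromatic carbon, meta to a (pyridazin-4-yl)carbamoyl group and para to a benzyloxy group: 4-hydroxypiperidin-1-yl in place of 2,6-dimethylmorpholin-4-yl on an aromatic carbon.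

Two large steps are on record, an at least 35-fold higher number from compound 1 to compound 2 (1.54 log units; beyond the scatter) and an at least 29-fold higher number from compound 1 to compound 3 (1.46 log units; beyond the scatter). Both replace trifluoromethyl, a group absent from compound 3 and compound 4, so they bear on this change only loosely. The closer guide is the exchange of pyrrolidin-1-yl for 2,6-dimethylmorpholin-4-yl, a 1.2-fold lower number from compound 2 to compound 3 (0.08 log units; within the scatter). On that single exchange, no step beyond the scatter is expected in this assay. The expected step is a 1.0-fold higher number from compound 3 to compound 4 (0.01 log units; within the scatter). For compound 4 the estimated value is 30000 nM, with an expected range of 12000 nM to 75000 nM.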

Compound 4, solubility: 28000 nM
Compound 4: the middle estimate sits 1.1-fold (0.03 log units) above what was measured; the measured number falls inside the stated range.
By their numbers in this assay, from the lowest: compounds 4, 3 and 2 (each within the scatter of the next). At a limit, below all of these: compound 1.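

In this assay, 4-hydroxypiperidin-1-yl brings a hydrogen-bond donor to this position and lacks the defined stereocentres of 2,6-dimethylmorpholin-4-yl, yet it gives a 1.0-fold lower number from compound 3 to compound 4 (0.02 log units; within the scatter), and in place of pyrrolidin-1-yl it gives a 1.3-fold lower number from compound 2 to compound 4 (0.10 log units; within the scatter). Compound 2, compound 3 and compound 4 thus cannot be told apart in this read-out, although the group they carry here differs each time, while the exchange for trifluoromethyl again stands out, with an at least 28-fold higher number from compound 1 to compound 4 (1.44 log units; beyond the scatter). The reading of compound 1 is a limit of the assay and not a number, so that step has no fixed size: the limit of < 1000 nM in this assay, at which 1 of the 4 values shown sits.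

It remains open whether a ring is needed here at all, since an open-chain group such as dimethylamino is not among the compounds shown. A charged group such as a carboxylic acid at this position also remains untested in what is shown.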